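Furan-2-yl for 1H-pyrrol-2-yl: a small measured step

The source may report more compounds than this note shows. Statements on the series, on what has been measured and on what is new or still open speak of the compounds shown alone.

Compound 1 `COc1ccc(CNC(=O)/C(C#N)=C/c2ccc[nH]2)cc1` and compound 3 `COc1ccc(CNC(=O)/C(C#N)=C/c2ccco2)cc1` share one core and differ in a single place, (furan-2-yl in place of 1H-pyrrol-2-yl on a double-bonded chain carbon bound to a double-bonded chain carbon). In a functional assay on MCF7 cells (Homo sapiens) for inhibition, read by MTT assay, with a stated time of 72 h (a higher number here means a weaker inhibitor of growth, a lower number a stronger inhibitor of growth), compound 1 gives 34000 nM, and compound 3 gives 27000 nM; the step of a 1.3-fold lower number from compound 1 to compound 3 (0.10 log units; within the scatter) is a small one. Compound 2 `N#C/C(=C\c1ccc[nH]1)C(=O)NCc1ccc(Cl)c(Cl)c1` is built on a different core; how its core differs from the core of compound 1 is not broken down here. In this assay compound 2 gives 6000 nM, the lowest of the three measured numbers, and its gaps to compound 3 and compound 1 both lie beyond the scatter. Compound 4 `N#C/C(=C\c1ccco1)C(=O)NCc1ccc(Cl)c(Cl)c1` has not yet been measured. It differs from compound 2 by furan-2-yl in place of 1H-pyrrol-2-yl on a double-bonded chain carbon bound to a double-bonded chain carbon. The place is described in the same words for both pairs, so this is the same change as from compound 1 to compound 3. For compound 4 the step is expected to be similar, a 1.3-fold lower number from compound 2 to compound 4 (0.11 log units; within the scatter), because the earlier step of a 1.3-fold lower number from compound 1 to compound 3 (0.10 log units; within the scatter) stayed within the scatter. The estimated value for compound 4 in this assay is 4700 nM, expected to fall between 2000 nM and 12000 nM.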

Compound 4, concentration for 50% growth inhibition: 20000 nM
For compound 4 the middle estimate is 4.3-fold (0.63 log units) below the measured one, outside the stated range (above it).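

In this assay, the same replacement of 1H-pyrrol-2-yl by furan-2-yl that made no readable difference on the core of compound 1 gives a 3.3-fold higher number from compound 2 to compound 4 (0.52 log units; beyond the scatter), so the result on one core did not carry over to the other: the same change on two cores in this assay, a 1.3-fold lower number (0.10 log units; within the scatter) from compound 1 to compound 3 and a 3.3-fold higher number (0.52 log units; beyond the scatter) from compound 2 to compound 4, 4.2-fold (0.62 log units) apart, beyond the scatter of two such steps. In this series, then, the outcome of this change depends on the core that carries it, and the small step seen earlier cannot be taken as a guide for the core of compound 2. Among these compounds, this rests on only one pair of compounds for each core, however, and it does not show which feature of the cores separates the two results, why they part, or that either result would hold on a further core.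

The compounds shown leave open how the same change behaves on any other core, and which part of the difference between the two cores matters. They also leave open what an amine or a carboxylic acid would give on a double-bonded chain carbon bound to a double-bonded chain carbon, on either core.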